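The source may report more compounds than this note shows. Statements on the series, on what has been measured and on what is new or still open speak of the compounds shown alone.

Compound 1 `O=C(CCC1=CCN(CCCc2ccc(Br)cc2)C1=O)NO` and compound 2 `O=C(CCC1=CCN(CCCc2ccc(Cl)cc2)C1=O)NO` share one core and differ only in chloro in place of bromo on an aromatic carbon. In a functional assay on NUGC-3 cells (Homo sapiens) for inhibition, read by sulforhodamine B assay (a lower number here means a stronger inhibitor of growth, a higher number a weaker inhibitor of growth), compound 1 gives 2200 nM, and compound 2 gives 2200 nM; the step is no change at the digits printed from compound 1 to compound 2 (within the scatter). Compound 3 `O=C(CCC1=CCN(Cc2ccc(Br)cc2)C1=O)NO` carries the bromo group on another core; how the two cores of compound 1 and compound 3 differ is not broken down here. In this assay compound 3 gives "not determined" (no result reported), so no number stands for it. Compound 4 `O=C(CCC1=CCN(Cc2ccc(Cl)cc2)C1=O)NO` is reached from compound 3 by chloro in place of bromo on an aromatic carbon, the same change as that from compound 1 to compound 2. Among the measured compounds shown here, the only guide to that change is no change at the digits printed from compound 1 to compound 2 (within the scatter); the step from compound 3 to compound 4 in this assay is expected to be of the same size, and this rests on that single pair alone. Compound 4 is therefore estimated at 3000 nM, between 800 nM and 12000 nM. That estimate leans on compound 2, which gives 2200 nM.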

Compound 4, concentration for 50% growth inhibition: 4280 nM
Compound 4: middle estimate off by 1.4-fold (0.15 log units), on the low side; the range from low to high includes it.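

Among the compounds shown here, with no number standing for compound 3 in this assay, no step from compound 3 to compound 4 can be read. The compounds shown leave open whether chloro in place of bromo behaves on the core of compound 3 as it does on the core of compound 1. No further data bear on this result.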